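Fluoro on the phenyl of compound 3

This account rests on a few compounds, and the source may have more. Where it says the series, first, only, none or still open, it means among the compounds named here.

In a functional assay on K562 cells (Homo sapiens) for antiproliferative activity, with a stated time of 72 h (a higher number here means a weaker inhibitor, a lower number a stronger inhibitor), compound 1 (`Nc1ncnn2c([C@@H]3O[C@H](CO)[C@@H](O)[C@H]3O)cc(C#CC3CC3)c12`) gives 40 nM. Compound 2 (`Nc1ncnn2c([C@@H]3O[C@H](CO)[C@@H](O)[C@H]3O)cc(C#Cc3ccc(F)cc3)c12`) gives > 100000 nM, which is a limit of the assay and not a number. Compound 3 (`Nc1ncnn2c([C@@H]3O[C@H](CO)[C@@H](O)[C@H]3O)cc(-c3ccccc3)c12`) gives > 100000 nM, which is also a limit and not a number. Compound 3 therefore stands at the limit of > 100000 nM in this assay, at which 2 of the 3 values shown sit.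

The change to compound 4 (`Nc1ncnn2c([C@@H]3O[C@H](CO)[C@@H](O)[C@H]3O)cc(-c3ccc(F)cc3)c12`) is fluoro in place of hydrogen on an aromatic carbon: phenyl becomes 4-fluorophenyl, para to a large group.

For the measured compounds named here, two measured steps bear on it, both large and beyond the scatter: an at least 2500-fold higher number from compound 1 to compound 2 (3.39 log units; beyond the scatter) and an at least 2500-fold higher number from compound 1 to compound 3 (3.39 log units; beyond the scatter). The third, a step that the two limits leave unreadable from compound 2 to compound 3, cannot be read. Among these compounds, the two with an aromatic ring in place of the cyclopropylethynyl end, compound 2 and compound 3, sit at the limit, and none goes against this. The 4-fluorophenyl group of compound 2 already came with > 100000 nM, a limit.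

No step beyond the scatter is therefore expected in this assay, and a second limit would leave the step unreadable. The expected step is a number no higher from compound 3 to compound 4 (the limit leaves the size open). For compound 4 the estimate is 100000 nM, with an expected range of 20000 nM to 300000 nM.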

Compound 4, half-maximal inhibitory concentration: > 100000 nM
Compound 4 ended at the assay's limit; the forecaster's own chance of this, stated with the estimate: 85%; the middle value lies on the limit itself.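

In this assay compound 4 gives > 100000 nM, which is a limit of the assay and not a number. The steps from compound 3 to compound 4 and from compound 2 to compound 4 cannot be read, so fluoro in place of hydrogen on this phenyl leaves no measurable activity to compare, and the result says nothing about the size of its effect. Only the comparison with the cyclopropylethynyl end can be read, as an at least 2500-fold higher number from compound 1 to compound 4 (3.39 log units; beyond the scatter), and with compound 4 the three compounds carrying an aromatic ring at this position, compound 2, compound 3 and compound 4, all sit at the same ceiling, with none among them going against it: the limit of > 100000 nM in this assay, at which 3 of the 4 values shown sit.

Still open, as far as these compounds go, is whether a different group on the phenyl, such as an amine or a carboxylic acid, would bring a compound of this kind off the limit. Also open, from the compounds shown here alone, is how much the triple-bonded end can vary from the cyclopropyl of compound 1, at 40 nM, for instance with a cyclobutyl ring or a longer chain.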